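Double-bond geometry in a cyclopropyl amide series

The source may report more compounds than this note shows. Statements on the series, on what has been measured and on what is new or still open speak of the compounds shown alone.

Measured in a functional assay on the whole organism (strain Icem-CET (SPF Caw)) for inhibition, with Mus musculus as the target, with a stated time of 30 min; on this read-out higher numbers stand for an effect only at larger amounts of compound and lower numbers for an effect already at smaller amounts:
compound 1 `C/C(C(=O)NC1CC1)=C(/C)c1ccc(Br)cc1` gives 8.2 mg/kg
compound 2 `C/C(C(=O)NC1CC1)=C(\C)c1ccc(Cl)cc1` gives 36.3 mg/kg

Compound 2 stands at the highest of the two numbers in this assay; its nearest neighbour, compound 1, lies well below it, beyond the scatter. Going by the values given here, compound 3 `C/C(C(=O)NC1CC1)=C(/C)c1ccc(Cl)cc1` is not yet measured. the two compounds have the same atoms and bonds and differ only in configuration as drawn: 1 of 1 stereo elements differ; a double bond is drawn Z in compound 2 and E in compound 3 The E drawing is the one compound 1 carries. A step down in this assay is expected, since compound 1 gives 8.2 mg/kg with that geometry. The expected step is a 3.0-fold lower number from compound 2 to compound 3 (0.48 log units; beyond the scatter). The estimate for compound 3 in this assay is 12 mg/kg, with a range from 4 mg/kg to 40 mg/kg.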

Compound 3, dose for half-maximal effect: 11.4 mg/kg
For compound 3 the middle estimate is 1.1-fold (0.02 log units) above the measured one; the range from low to high includes it.
By their numbers in this assay, from the lowest: compounds 1 and 3 (each within the scatter of the next); then compound 2.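

In this assay double-bond geometry alone moves the number, with a 3.2-fold lower number from compound 2 to compound 3 (0.50 log units; beyond the scatter) and the E drawing on the lower side. This separation can be assigned to geometry alone: the fact that compounds 2 and 3 differ only in the configuration as drawn. With the E drawing held, chloro in place of bromo on an aromatic carbon gives a 1.4-fold higher number from compound 1 to compound 3 (0.14 log units; within the scatter) and so does not separate the two halogens here.

As far as these compounds go, whether the same geometry step holds with bromo remains open. In this assay, from the compounds shown here alone, it also remains open how an amine or a carboxylic acid on the aromatic carbon, or a longer chain in place of cyclopropyl, would read.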